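Two Aryl Hydroxyls in Place of One Methoxy

This account rests on a few compounds, and the source may have more. Where it says the series, first, only, none or still open, it means among the compounds named here.

Compound 1 `C=C/C=C\[C@H](C)[C@H](OC(N)=O)[C@@H](C)[C@H](O)[C@@H](C)C/C(C)=C\[C@H](C)[C@@H](O)[C@@H](C)/C=C\CCc1cccc(Cl)c1`: 380 nM
Compound 2 `C=C/C=C\[C@H](C)[C@H](OC(N)=O)[C@@H](C)[C@H](O)[C@@H](C)C/C(C)=C\[C@H](C)[C@@H](O)[C@@H](C)/C=C\CCc1cccc(OC)c1`: 370 nM
Compound 3 `C=C/C=C\[C@H](C)[C@H](OC(N)=O)[C@@H](C)[C@H](O)[C@@H](C)C/C(C)=C\[C@H](C)[C@@H](O)[C@@H](C)/C=C\CCc1cccc(F)c1`: 400 nM

The three measured compounds share one core and differ only in the single substituent on the aromatic ring. In a functional assay on SK-OV-3 cells (Homo sapiens) for cytotoxicity (on this read-out lower numbers stand for stronger inhibition and higher numbers for weaker inhibition), compound 1 gives 380 nM, compound 2 gives 370 nM, and compound 3 gives 400 nM. Compound 2 holds the lowest of the three numbers, yet the steps of a 1.0-fold lower number from compound 1 to compound 2 (0.01 log units; within the scatter) and a 1.1-fold higher number from compound 2 to compound 3 (0.03 log units; within the scatter) both fall within the scatter, as does a 1.1-fold higher number from compound 1 to compound 3 (0.02 log units; within the scatter), so the three cannot be told apart on these data.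

Compound 4 `C=C/C=C\[C@H](C)[C@H](OC(N)=O)[C@@H](C)[C@H](O)[C@@H](C)C/C(C)=C\[C@H](C)[C@@H](O)[C@@H](C)/C=C\CCc1cc(O)cc(O)c1` awaits measurement. Its change from compound 2 is 3,5-dihydroxyphenyl in place of 3-methoxyphenyl on a saturated chain carbon, two bonds along the chain from a double-bonded chain carbon. All three measured steps concern one substituent on that ring and none moved this assay beyond the scatter, which is the only bearing they offer. Among the compounds with values here, no measured step introduces a hydroxyl or a second substituent, so the expectation is indirect and wide. Compound 4 is therefore expected to give roughly 450 nM, within 150 nM to 1500 nM. The step this estimate implies, a 1.2-fold higher number from compound 2 to compound 4 (0.09 log units; within the scatter), is expected to stay close to the scatter.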

Compound 4, half-maximal inhibitory concentration: 40 nM
Estimate against measurement, compound 4: 11-fold (1.05 log units) above; the measured number lies below the stated range.
By their numbers in this assay, from the lowest: compound 4; then compounds 2, 1 and 3 (each within the scatter of the next).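

In this assay, within the data shown here, the aromatic ring at the end of the chain proves to be a position that can move the number well beyond the scatter, which the single substituents of compounds 1, 2 and 3 never did: 3,5-dihydroxyphenyl gives a 9.3-fold lower number from compound 2 to compound 4 (0.97 log units; beyond the scatter), together with a 9.5-fold lower number from compound 1 to compound 4 (0.98 log units; beyond the scatter) and a 10-fold lower number from compound 3 to compound 4 (1.00 log units; beyond the scatter). Against 3-methoxyphenyl, the change keeps 8 heavy atoms and goes from 0 hydrogen-bond donors to 2 hydrogen-bond donors, so a step of this size occurs with no change in heavy-atom count. Nothing in the data shown accounts for the size of the step.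

Compound 4 replaces the methoxy and adds a second substituent in one move, so the contribution of one hydroxyl cannot be separated from that of the pair. Going by these compounds, whether 3,5-dimethoxyphenyl, or an amine or a carboxylic acid on the ring, would give a similar step remains open.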